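This account rests on a few compounds, and the source may have more. Where it says the series, first, only, none or still open, it means among the compounds named here.

Measured in an ADME assay on MT4 cells (Homo sapiens) for cytotoxicity, read by MTT assay; on this read-out lower numbers stand for higher toxicity in this test and higher numbers for lower toxicity in this test:
- compound 1 `CCCCC1C(=O)N(O)C(=O)c2ccccc21` gives 25400 nM
- compound 2 `O=c1c2ccccc2c(Cc2ccccc2)c(O)n1O` gives 88000 nM
- compound 3 `CCC1C(=O)N(O)C(=O)c2ccccc21` gives 250000 nM

Compound 1 has the lowest number of the three, and its gaps to compound 2 and compound 3 both lie beyond the usual scatter. The next compound to read is compound 4 `CCCCCC1C(=O)N(O)C(=O)c2ccccc21`, with this change from compound 1: methyl in place of hydrogen on a saturated chain carbon, four bonds along the chain from a saturated ring carbon.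

Going by the values given here, one measured step bears on this, and it also concerns the chain: a 9.8-fold higher number from compound 1 to compound 3 (0.99 log units; beyond the scatter). That step is modest, and it shortens the chain where the new change extends it. A step to a lower number is therefore expected in this assay, probably smaller than the measured one, since less is added than was removed there. Compound 2 is not linked by any measured step and adds nothing here. A single step gives only weak support for this trend. The expected step is a 2.5-fold lower number from compound 1 to compound 4 (0.40 log units; beyond the scatter). For compound 4 the estimated value is 10000 nM, with an expected range of 4000 nM to 25000 nM.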

Compound 4, half-maximal cytotoxic concentration: 98300 nM
Compound 4: the middle estimate sits 9.8-fold (0.99 log units) below what was measured; the measured number lies above the stated range.
By their numbers in this assay, from the lowest: compound 1; then compounds 2 and 4 (each within the scatter of the next); then compound 3.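

In this assay, the number does not move in one direction with chain length: methyl in place of hydrogen, four bonds along the chain from a saturated ring carbon, gives a 3.9-fold higher number from compound 1 to compound 4 (0.59 log units; beyond the scatter), the same direction as the shortened chain in a 9.8-fold higher number from compound 1 to compound 3 (0.99 log units; beyond the scatter). Compound 4 still stays on the lower side of compound 3, with a 2.5-fold lower number from compound 3 to compound 4 (0.41 log units; beyond the scatter), so among compounds 1, 3 and 4 the lowest number belongs to the intermediate chain, that of compound 1. No data at hand explain this turn.

From the compounds shown here alone, whether a longer chain would raise the number further remains open, as does the effect of a branched chain or of a chain ending in an amine or a carboxylic acid. Going by these compounds, compound 2 differs from the others in more than one place, so its place in this trend also remains open.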